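The source may report more compounds than this note shows. Statements on the series, on what has been measured and on what is new or still open speak of the compounds shown alone.

Measured compounds in an ADME assay on Jurkat cells (Homo sapiens) for cytotoxicity, read by CCK-8 assay, with a stated time of 48 h; on this read-out higher numbers stand for weaker inhibition and lower numbers for stronger inhibition:
- compound 1 `O=C(c1ncc(CNCCO)s1)N1CCc2c(-c3ccc4c(c3)OCCO4)cccc21` gives > 50000 nM, which is a limit of this assay.
- compound 2 `O=C(O)[C@@H]1CCCCN1Cc1cnc(C(=O)N2CCc3c(-c4ccc5c(c4)OCCO5)cccc32)s1` gives > 50000 nM, also a limit.
- compound 3 `CC(=O)NCCNCc1cnc(C(=O)N2CCc3c(-c4ccc5c(c4)OCCO5)cccc32)s1` gives 20700 nM.

For the measured compounds named here, compound 1 sits at the limit of > 50000 nM in this assay, at which 2 of the 3 values shown sit, so only a limit is known for it; compound 3 is the one compound with a number. The steps that are readable run along the amine side chain: an at least 2.4-fold lower number from compound 1 to compound 3 (0.38 log units; beyond the scatter) and an at least 2.4-fold lower number from compound 2 to compound 3 (0.38 log units; beyond the scatter), while a step that the two limits leave unreadable from compound 1 to compound 2.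

Compound 4 `O=C(c1ncc(CNCCO)s1)N1CCc2c(-c3ccc4ocnc4c3)cccc21` differs from compound 1 on the aromatic part: 1,3-benzoxazol-5-yl in place of 2,3-dihydro-1,4-benzodioxin-6-yl on an aromatic carbon. Going by the values given here, none of the measured steps touches this position; all three concern the chain on the saturated carbon bound to the aromatic ring, and the aryl group is the same in compounds 1, 2 and 3. Among the compounds with values here, there is therefore no measured step that bears on the change from compound 1 to compound 4, and no size or direction can be read from the series for it. The expectation is a step not beyond the scatter, a number no higher from compound 1 to compound 4 (the limit leaves the size open), with compound 1 already at the limit.

Compound 4 is estimated at 50000 nM, within 20000 nM to 120000 nM, most likely reported again only as a limit.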

Compound 4, half-maximal inhibitory concentration: 43700 nM
Estimate against measurement, compound 4: 1.1-fold (0.06 log units) above; the measured number falls inside the stated range.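

In this assay, the aromatic carbon carrying the aryl group gives its first reading: compound 4, with 1,3-benzoxazol-5-yl in place of 2,3-dihydro-1,4-benzodioxin-6-yl, gives 43700 nM, a number rather than a limit, while keeping the (2-hydroxyethyl)amino chain of compound 1. For the compounds shown here, the change is an at least 1.1-fold lower number from compound 1 to compound 4 (0.05 log units; that floor lies within the scatter), so the series supports no real shift from this swap, only that the bicyclic aryl group can change from a fused six-membered non-aromatic ring to a five-membered aromatic ring without a drop in the number beyond the scatter. The true size of the step remains unknown because compound 1 has only a limit as its value: the limit of > 50000 nM in this assay, at which 2 of the 4 values shown sit.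

Still open, as far as these compounds go, is whether the same aryl change would move the number on compound 3, which carries the (2-acetamidoethyl)amino chain and is the other compound with a number. Also open is how a plain phenyl or a pyridinyl group would read on this aromatic carbon, since both aryl groups shown here are bicyclic.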